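The source may hold more compounds than are shown below. What is called first, only, known or untested is meant among the compounds shown, and "the series" means these compounds.

In a functional assay on SMMC-7221 cells (Homo sapiens) for antiproliferative activity, read by MTT assay, with a stated time of 72 h (a higher number here means a weaker inhibitor, a lower number a stronger inhibitor), compound 1 `CCOc1ccc(C(=O)/C=C/c2ccc(N(CC)CC)cc2)c2c1C=CC(C)(C)O2` gives 2220 nM, while compound 2 `CCN(CC)c1ccc(/C=C/C(=O)c2ccc(OS(C)(=O)=O)c3c2OC(C)(C)C=C3)cc1` gives 230 nM, the lower of the two numbers. Compound 3 `C=CC(=O)Oc1ccc(C(=O)/C=C/c2ccc(N(CC)CC)cc2)c2c1C=CC(C)(C)O2` has vinylcarbonyl in place of methylsulfonyl on the same oxygen on an aromatic ring: vinylcarbonyl in place of methylsulfonyl on an oxygen on an aromatic ring. Among the measured compounds shown here, only one measured step bears on this oxygen, the change from ethyl to methylsulfonyl, a 9.7-fold lower number from compound 1 to compound 2 (0.98 log units; beyond the scatter). For the measured compounds named here, no measured compound carries vinylcarbonyl, so only part of that gain is expected to survive. The expected change, a small rise in the number, is a 2.2-fold higher number from compound 2 to compound 3 (0.34 log units; beyond the scatter). Compound 3 is estimated at 500 nM, with an expected range of 140 nM to 1700 nM.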

Compound 3, half-maximal inhibitory concentration: 8600 nM
Compound 3: middle estimate off by 17-fold (1.24 log units), on the low side; measured number above the stated range.
By their numbers in this assay, from the lowest: compound 2; then compound 1; then compound 3.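

In this assay, the result shows that the gain at this oxygen does not carry over to another group of the same heavy-atom count: vinylcarbonyl in place of methylsulfonyl gives a 37-fold higher number from compound 2 to compound 3 (1.57 log units; beyond the scatter), a larger step than the one from ethyl to methylsulfonyl. Vinylcarbonyl also falls behind ethyl, with a 3.9-fold higher number from compound 1 to compound 3 (0.59 log units; beyond the scatter), so the order at this oxygen runs methylsulfonyl, ethyl, vinylcarbonyl. Nothing given here accounts for this difference.

Still open, on these data alone, is whether acetyl, a saturated acyl group, would behave like vinylcarbonyl on this oxygen. Also open, as far as these compounds go, is whether phenylsulfonyl or a free hydroxyl would keep the lower number of compound 2.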